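Lengthening the chain from compound 3 to compound 4

This account rests on a few compounds, and the source may have more. Where it says the series, first, only, none or still open, it means among the compounds named here.

Measured in a functional assay on MGC-803 cells (Homo sapiens) for antiproliferative activity, read by MTT assay, with a stated time of 48 h; a higher number here means a weaker inhibitor, a lower number a stronger inhibitor:
Compound 1 `COc1ccc(CN(C(=O)CSc2ccccn2)c2cc(OC)c(OC)c(OC)c2)cc1`: 2410 nM
Compound 2 `COc1ccc(CN(C(=O)CSc2nc3ccc(OC)cc3s2)c2cc(OC)c(OC)c(OC)c2)cc1`: 1270 nM
Compound 3 `COc1ccc(CN(C(=O)CCSc2nc3ccccc3o2)c2cc(OC)c(OC)c(OC)c2)cc1`: 640 nM

Compound 3 cannot be separated from compound 2, as the record shows a 2.0-fold lower number from compound 2 to compound 3 (0.30 log units; within the scatter). Its clear gap is to compound 1, with a 3.8-fold lower number from compound 1 to compound 3 (0.58 log units; beyond the scatter).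

The next compound is compound 4 `COc1ccc(CN(C(=O)CCCSc2nc3ccccc3o2)c2cc(OC)c(OC)c(OC)c2)cc1`, and the change is ((1,3-benzoxazol-2-yl)sulfanyl)methyl in place of (1,3-benzoxazol-2-yl)sulfanyl on a saturated chain carbon, two bonds along the chain from a carbonyl carbon. In words, this is ((1,3-benzoxazol-2-yl)sulfanyl)methyl in place of (1,3-benzoxazol-2-yl)sulfanyl on a saturated chain carbon, two bonds along the chain from a carbonyl carbon.

For the measured compounds named here, no measured step alters the chain alone. The two steps into compound 3 above come closest, but each also swaps the group on sulfur. A swap on sulfur by itself gave a 1.9-fold lower number from compound 1 to compound 2 (0.28 log units; within the scatter). The evidence is therefore indirect, and it points at most to a slightly lower number in this assay, probably no change beyond the scatter.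

The expected change is a 1.1-fold lower number from compound 3 to compound 4 (0.03 log units; within the scatter).

For compound 4 the estimate is 600 nM, with an expected range of 200 nM to 1800 nM.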

Compound 4, half-maximal inhibitory concentration: 1290 nM
Estimate against measurement, compound 4: 2.2-fold (0.33 log units) below, and the stated range covers the measured number.
By their numbers in this assay, from the lowest: compounds 3, 2, 4 and 1 (each within the scatter of the next, the first and the last beyond it).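

For the compounds shown here, compound 4 gives the first reading of the chain alone, with the (1,3-benzoxazol-2-yl)sulfanyl group kept the same. In this assay this step (a 2.0-fold higher number from compound 3 to compound 4 (0.30 log units; within the scatter)) cannot be told from the usual scatter, so the longer chain and the shorter one are not separated here. Compound 4 also stays within the scatter of both other compounds (a 1.0-fold higher number from compound 2 to compound 4 (0.01 log units; within the scatter); a 1.9-fold lower number from compound 1 to compound 4 (0.27 log units; within the scatter)), so the clear gap seen for compound 3 against compound 1 does not carry over to compound 4, and no measurement shown offers an explanation for these readings.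

Two chain lengths alone cannot show whether chain length matters at this position. A still longer chain, or an amine or carboxylic acid on the chain in place of the (1,3-benzoxazol-2-yl)sulfanyl group, remains an open case.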